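Three Measured Analogues and an Untested Fourth

The source may hold more compounds than are shown below. What is called first, only, known or untested is meant among the compounds shown, and "the series" means these compounds.

The measured compounds, all tested in a functional assay on HepG2 cells (Homo sapiens) for inhibition, read by MTT assay, with a stated time of 3 days; on this read-out higher numbers stand for weaker inhibition and lower numbers for stronger inhibition:
compound 1, `COc1cc(-c2nc3ccccc3s2)ccc1OCC(=O)NNC(=O)CCl`, gave 2890 nM
compound 2, `COc1cc(-c2nc3ccccc3s2)ccc1OCC(=O)NNC(=O)CN(C(C)=O)[C@@H](CS)C(=O)O`, gave 3420 nM
compound 3, `CCOC(=O)[C@H](CS)NCC(=O)NNC(=O)COc1ccc(-c2nc3ccccc3s2)cc1OC`, gave 3760 nM

Compound 2 stands second highest of the three numbers; its nearest neighbour is compound 3, with a 1.1-fold higher number from compound 2 to compound 3 (0.04 log units; within the scatter), and its furthest is compound 1, with a 1.2-fold higher number from compound 1 to compound 2 (0.07 log units; within the scatter), both within the scatter. The untested compound 4, `CCOC(=O)[C@H](CS(=O)(=O)O)NCC(=O)NNC(=O)COc1ccc(-c2nc3ccccc3s2)cc1OC`, differs from compound 2 at one place: (1-(ethoxycarbonyl)-2-sulfoethyl)amino in place of acetyl(1-carboxy-2-sulfanylethyl)amino on a saturated chain carbon bound to a carbonyl carbon. Going by the values given here, the steps that bear on this are those at the same saturated chain carbon, a 1.2-fold higher number from compound 1 to compound 2 (0.07 log units; within the scatter), a 1.3-fold higher number from compound 1 to compound 3 (0.11 log units; within the scatter) and a 1.1-fold higher number from compound 2 to compound 3 (0.04 log units; within the scatter), none of them beyond the scatter. Among the compounds with values here, no measured step alters the sulfanyl group itself, so that part of the change is uninformed. A step within the scatter is therefore expected in this assay. Compound 4 is estimated at 3600 nM, in the range 1600 nM to 8000 nM. The expected step is a 1.1-fold higher number from compound 2 to compound 4 (0.02 log units; within the scatter).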

Compound 4, half-maximal inhibitory concentration: 3360 nM
Beside the measured number, compound 4's estimate is 1.1-fold (0.03 log units) above it; low and high end bracket the measured number.
By their numbers in this assay, from the lowest: compounds 1, 4, 2 and 3 (each within the scatter of the next).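

In this assay, going by these compounds alone, sulfo in place of sulfanyl, the one step that alters the sulfanyl group itself, gives a 1.1-fold lower number from compound 3 to compound 4 (0.05 log units; within the scatter). The whole (1-(ethoxycarbonyl)-2-sulfoethyl)amino group gives a 1.0-fold lower number from compound 2 to compound 4 (0.01 log units; within the scatter) in place of acetyl(1-carboxy-2-sulfanylethyl)amino and a 1.2-fold higher number from compound 1 to compound 4 (0.07 log units; within the scatter) in place of chloro, so all steps at this saturated chain carbon remain within the scatter. No measurement here explains this result. Still open, going by these compounds, is whether a carboxylic acid in place of the ethoxycarbonyl group, or a longer chain carrying the sulfo group, would give a step beyond the scatter.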